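A few compounds are considered here, and "the series" means these few. Any claim that something is new, unique, unknown or untested is made for them only; others in the source may bear on it.

In a functional assay on HCT-15 cells (Homo sapiens) for antiproliferative activity (on this read-out higher numbers stand for weaker inhibition and lower numbers for stronger inhibition), compound 1 (`COc1ccc(S(=O)(=O)Oc2ccccc2NC(=O)c2ccccn2)cc1`) gives 110 nM. Compound 2 (`COc1ccc(S(=O)(=O)Oc2ccccc2NC(=O)c2ccc3ncccc3c2)cc1`) gives > 10000 nM, which is a limit of the assay and not a number. Compound 3 (`COc1ccc(S(=O)(=O)Oc2ccccc2NC(=O)c2ccco2)cc1`) differs from it as follows: furan-2-yl in place of quinolin-6-yl on a carbonyl carbon. Within the data shown here, the one measured step at this place, an at least 90-fold higher number from compound 1 to compound 2 (1.95 log units; beyond the scatter), is large, so moving away from quinolin-6-yl is expected to bring a large change towards a lower number in this assay. The expected step is an at least 25-fold lower number from compound 2 to compound 3 (1.39 log units; beyond the scatter). For compound 3 the estimate is 400 nM, with an expected range from 60 nM to 4000 nM.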

Compound 3, half-maximal inhibitory concentration: 19 nM
Estimate against measurement, compound 3: 21-fold (1.32 log units) above; the whole stated range lies above it.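

On the carbonyl carbon, a five-membered aromatic ring does more in this assay than either six-membered-ring-bearing group: furan-2-yl brings an at least 520-fold lower number from compound 2 to compound 3 (2.72 log units; beyond the scatter), and also a 5.8-fold lower number from compound 1 to compound 3 (0.76 log units; beyond the scatter). Compound 3 therefore has the lowest number of the three, with both steps beyond the scatter. The first step has only a lower bound, since compound 2 stands at a limit of the assay and not at a number: the limit of > 10000 nM in this assay, at which 1 of the 3 values shown sits.

The compounds shown leave open whether thiophen-2-yl or plain phenyl would match furan-2-yl at this place. They also leave open how an open chain carrying an amine would fare there.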